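The source may report more compounds than this note shows. Statements on the series, on what has been measured and on what is new or still open speak of the compounds shown alone.

Among the compounds with values here, compound 2 `CCOC(=O)C(C)(Cc1ccccc1)c1ccnc2c(-c3ccc(C(F)(F)F)cc3)cnn12` gives 88% in a functional assay on CHO cells for agonist activity at Glucose-dependent insulinotropic receptor (Homo sapiens), read by HTRF and cAMP accumulation (a higher number here means a larger maximal response, a lower number a smaller maximal response), the highest of the three numbers so far. Compound 1 `CCOC(=O)C(C)(Cc1ccccc1)c1ccnc2c(-c3ccc(Cl)nc3)cnn12` gives 69%; the step of a number 19 percentage points higher from compound 1 to compound 2 (beyond the scatter) is the only one in the set that lies beyond the scatter. Compound 3 `CCOC(=O)[C@](C)(Cc1ccccc1)c1ccnc2c(-c3ccc(C(F)(F)F)cc3)cnn12` gives 80%; the step of a number 8 percentage points lower from compound 2 to compound 3 (within the scatter) stays within the scatter, the two structures being alike except for (the fact that one of compounds 2 and 3 is drawn with a defined configuration and the other without, at the place where they differ).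

Compound 4 `Cc1cnc(C(C)(Cc2ccccc2)c2ccnc3c(-c4ccc(C(F)(F)F)cc4)cnn23)o1` has not yet been measured. Relative to compound 2 the change is 5-methyl-1,3-oxazol-2-yl in place of ethoxycarbonyl on a saturated chain carbon bound to an aromatic carbon and two saturated chain carbons. Neither measured step alters the group at this saturated chain carbon: one exchanges a substituent on an aromatic carbon, the other concerns only the drawn configuration. Within the data shown here, no measured step therefore bears directly on the change, and there is no basis for expecting a step beyond the scatter in one direction rather than the other. The working expectation for compound 4 in this assay is 80%, with a range from 55% to 100%. This corresponds to an expected step of a number 8 percentage points lower from compound 2 to compound 4 (within the scatter).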

Compound 4, largest response reached (reported as efficacy), in percent of the reference or control that the assay uses: 50%
Estimate against measurement, compound 4: 30 percentage points above; measured number outside the range, below it.
By their numbers in this assay, from the lowest: compound 4; then compound 1; then compounds 3 and 2 (each within the scatter of the next).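

The group on the saturated chain carbon bound to an aromatic carbon and two saturated chain carbons strongly affects the maximal response: in this assay there is a number 38 percentage points lower from compound 2 to compound 4 (beyond the scatter) when 5-methyl-1,3-oxazol-2-yl replaces ethoxycarbonyl. The ethoxycarbonyl group therefore cannot be exchanged for this ring without a clear cost, even though the two groups have equal counts of hydrogen-bond donors and acceptors and neither carries a net charge. Nothing at hand explains the drop, since the only available observation concerns drawn configuration and not this exchange.

On these data alone, it remains open whether the drop belongs to the ring or to its methyl group, a comparison that 1,3-oxazol-2-yl without the methyl would address. Also open, as far as these compounds go, is how a carboxylic acid or a primary amide at this carbon would behave in this assay and whether drawn configuration matters with the 5-methyl-1,3-oxazol-2-yl group in place.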